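Methyl shifted on the aryl hydrazone ring

The compounds below may be only part of what the source reports. "The series", "measured", "known", "first", "only" and "open" are said of these compounds alone.

Three members of the series have been measured, and all share one core. Compound 1 `Clc1ccc(-c2csc(N/N=C/c3ccccc3)n2)cc1` is the parent without a substituent on the outer ring; in an in vitro assay on BTI-TN-5B1-4 cells for inhibition of Amine oxidase [flavin-containing] B (Homo sapiens), read by fluorescence, with a stated time of 15 min, tested at 100 uM (on this read-out higher numbers stand for more inhibition at the one concentration tested (going by the name of the read-out) and lower numbers for less inhibition), compound 1 gives 40%. Compound 2 `COc1ccc(/C=N/Nc2nc(-c3ccc(Cl)cc3)cs2)cc1` adds a methoxy and gives 40%; compound 3 `Cc1ccccc1/C=N/Nc1nc(-c2ccc(Cl)cc2)cs1` adds a methyl and gives 40%. The step of no change at the digits printed from compound 1 to compound 2 (within the scatter) and the step of no change at the digits printed from compound 1 to compound 3 (within the scatter) both stay within the scatter, so compound 3 stands level with compounds 1 and 2, with no ordering among the three.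

Compound 4 `Cc1ccc(/C=N/Nc2nc(-c3ccc(Cl)cc3)cs2)cc1` is not yet measured. It differs from compound 3 by 4-methylphenyl in place of 2-methylphenyl on a carbon with a double bond to nitrogen. For the measured compounds named here, no measured step compares two placements of the same group, so the steps that bear on it are only those that put a methoxy or a methyl onto the ring, no change at the digits printed from compound 1 to compound 2 (within the scatter) and no change at the digits printed from compound 1 to compound 3 (within the scatter), neither of which moved beyond the scatter. The expected step of no change at the digits printed from compound 3 to compound 4 (within the scatter) is therefore none beyond the scatter. Compound 4 is estimated at 40%, with a range from 25% to 55%.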

Compound 4, a percentage reported as inhibition, at one concentration (the size of the read-out at that concentration, not a potency): 40%
Estimate against measurement, compound 4: no gap at the digits printed, and the stated range covers the measured number.
By their numbers in this assay, from the lowest: compounds 1, 2, 3 and 4 (each within the scatter of the next).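

In this assay, for the compounds shown here, 4-methylphenyl in place of 2-methylphenyl on a carbon with a double bond to nitrogen gives no change at the digits printed from compound 3 to compound 4 (within the scatter) and is the first comparison of two placements of one group, so moving the methyl has no effect beyond the scatter on this read-out. The other two new comparisons agree: methyl in place of methoxy on an aromatic carbon gives no change at the digits printed from compound 2 to compound 4 (within the scatter) and methyl in place of hydrogen on an aromatic carbon gives no change at the digits printed from compound 1 to compound 4 (within the scatter), so the unsubstituted parent, the methoxy compound and both methyl placements all remain level, with no order among the four. No measured information is available to explain this flat result.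

From the compounds shown here alone, whether a carboxylic acid, an amine or a longer chain such as butyl on the outer ring would move this assay beyond the scatter remains open. A read-out at one concentration also leaves open whether compounds 1, 2, 3 and 4 would separate in a full concentration series.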